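This account rests on a few compounds, and the source may have more. Where it says the series, first, only, none or still open, it means among the compounds named here.

Measured so far, in a functional assay on NCI-H1299 cells (Homo sapiens) for inhibition, read by CCK-8 assay, with a stated time of 72 h, tested at 1 uM; on this read-out higher numbers stand for a stronger effect at the one concentration tested and lower numbers for a weaker effect:
- compound 1 `CN(C)C(=O)c1cc2cnc(Nc3ccc(C(=O)NCCCCN=C=S)cc3)nc2n1C1CCCC1` gives 55.2%
- compound 2 `CN(C)C(=O)c1cc2cnc(Nc3ccc(C(=O)NCCCCCCN=C=S)cc3)nc2n1C1CCCC1` gives 49.4%
- compound 3 `CN(C)C(=O)c1cc2cnc(Nc3ccc(C(=O)NCCCCN=C=S)cc3F)nc2n1C1CCCC1` gives 28.7%

Compound 3 stands lowest of the three numbers. The step of a number 26.5 percentage points lower from compound 1 to compound 3 (beyond the scatter) is beyond the scatter, and compound 2 sits above compound 3 by a gap that is also beyond the scatter; the change from compound 1 to compound 3 is fluoro in place of hydrogen on an aromatic carbon.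

Compound 4 `CN(C)C(=O)c1cc2cnc(Nc3ccc(C(=O)NCCCCCCN=C=S)cc3F)nc2n1C1CCCC1` has not yet been measured in this assay. It differs from compound 3 in one place: a group of 5 heavy atoms (3 carbon, 1 nitrogen, 1 sulfur; no ring) in place of a group of 3 heavy atoms (1 carbon, 1 nitrogen, 1 sulfur; no ring), on a saturated chain carbon, four bonds along the chain from an amide-type nitrogen. The same change has been measured once in the series, in the step of a number 5.8 percentage points lower from compound 1 to compound 2 (within the scatter), and that step stayed within the scatter. For the measured compounds named here, compound 3 and compound 4 carry the fluoro that compound 1 and compound 2 lack, so this single step is the only guide, and it gives no ground to expect a shift beyond the scatter here either.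

On that basis the step from compound 3 to compound 4 is expected to be a number 3.7 percentage points lower from compound 3 to compound 4 (within the scatter), within the scatter. Compound 4 is therefore estimated to give 25% in this assay, with a range from 12% to 40%.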

Compound 4, a percentage reported as inhibition, at one concentration (the size of the read-out at that concentration, not a potency): 29.1%
Beside the measured number, compound 4's estimate is 4.1 percentage points below it; the measured number falls inside the stated range.
By their numbers in this assay, from the lowest: compounds 3 and 4 (each within the scatter of the next); then compounds 2 and 1 (each within the scatter of the next).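

In this assay, the group of 5 heavy atoms in place of the group of 3 heavy atoms, on a saturated chain carbon, four bonds along the chain from an amide-type nitrogen, now also stays within the scatter when the fluoro is present, giving a number 0.4 percentage points higher from compound 3 to compound 4 (within the scatter). This change has therefore been read on two cores, and the two steps agree: the same change on two cores in this assay, a number 5.8 percentage points lower (within the scatter) from compound 1 to compound 2 and a number 0.4 percentage points higher (within the scatter) from compound 3 to compound 4, 6.2 percentage points apart, within the scatter of two such steps

The fluoro in place of hydrogen on an aromatic carbon keeps its effect with the longer of the two groups, giving a number 20.3 percentage points lower from compound 2 to compound 4 (beyond the scatter), so its step does not depend on which of these two groups is present: the same change on two cores in this assay, a number 26.5 percentage points lower (beyond the scatter) from compound 1 to compound 3 and a number 20.3 percentage points lower (beyond the scatter) from compound 2 to compound 4, 6.2 percentage points apart, within the scatter of two such steps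

The compounds shown leave open whether a still longer chain, or an amine or a carboxylic acid in place of the group at this position, would move the read-out beyond the scatter, and whether chloro in place of the fluoro would give a step of similar size. Going by these compounds, a read-out at one concentration gives the size of the effect there and not a potency, so any difference in potency within each pair that lies within the scatter remains unknown.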